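Mirror-image pair: inverting both ring stereocentres

The source may hold more compounds than are shown below. What is called first, only, known or untested is meant among the compounds shown, and "the series" means these compounds.

For the measured compounds named here, compound 2 `Cc1cc(N2C[C@@H]3CCNC[C@@H]32)cnc1Cl` holds the highest of the two numbers measured so far in a functional assay on HEK293 cells for agonist activity at Neuronal acetylcholine receptor; alpha3/beta4 (Homo sapiens), read by FLIPR (a higher number here means that more compound is needed for the effect, a lower number that less compound is needed), giving 1910 nM, while compound 1 `Clc1ccc(N2C[C@H]3CCNC[C@H]32)cn1` gives 1520 nM, a gap within the scatter. Compound 3 `Cc1cc(N2C[C@H]3CCNC[C@H]32)cnc1Cl` has not yet been measured. It differs from compound 2 as follows: the two compounds have the same atoms and bonds and differ only in configuration as drawn: 2 of 2 stereo elements differ (all stereocentres are inverted: mirror images); a stereocentre at a saturated ring carbon is drawn S in compound 2 and R in compound 3; a stereocentre at a saturated ring carbon is drawn R in compound 2 and S in compound 3. Going by the values given here, no measured pair shows what inverting configuration does here, so the step from compound 2 to compound 3 is expected to be a 1.3-fold lower number from compound 2 to compound 3 (0.10 log units; within the scatter), with no direction beyond the scatter favoured. Compound 3 is therefore estimated at 1500 nM, between 300 nM and 7000 nM.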

Compound 3, half-maximal effective concentration: 298 nM
The estimate for compound 3 lay 5.0-fold (0.70 log units) above the measured number, and the stated range ends above it.
By their numbers in this assay, from the lowest: compound 3; then compounds 1 and 2 (each within the scatter of the next).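

Configuration matters on this core: inverting both ring stereocentres gives a 6.4-fold lower number from compound 2 to compound 3 (0.81 log units; beyond the scatter) in this assay, something no earlier pair could show. The step can be traced to the stereocentres alone: the fact that compounds 2 and 3 differ only in the configuration as drawn

With the configuration kept as drawn, methyl in place of hydrogen on an aromatic carbon gives a 5.1-fold lower number from compound 1 to compound 3 (0.71 log units; beyond the scatter), so the methyl goes with a lower number in this configuration. From the compounds shown here alone, it remains open whether methyl would give a similar step in the opposite configuration. Also open, going by these compounds, is how an ethyl or methoxy group in its place would read.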